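Removing a Second Methyl from Compound 1

This account rests on a few compounds, and the source may have more. Where it says the series, first, only, none or still open, it means among the compounds named here.

compound 1 `COc1cc(/C=N/Nc2nc3ccccc3s2)cc(OC)c1O`: 36%
compound 2 `COc1cc(/C=N/NC(=O)c2ccncc2)cc(OC)c1OC`: 95%
compound 3 `COc1cc(/C=N/Nc2nc3ccccc3s2)cc(OC)c1OC`: 100%

In a physicochemical assay on cells (Homo sapiens), with a stated time of 18 h, tested at 1 uM (on this read-out lower numbers stand for a stronger effect and higher numbers for a weaker effect at the one concentration tested), compound 1 gives the lowest of the three numbers, that is the strongest effect, with compound 2 and compound 3 both far higher, beyond the scatter. Compound 4 `COc1cc(/C=N/Nc2nc3ccccc3s2)cc(O)c1O` differs from compound 1 by hydrogen in place of methyl on an oxygen on an aromatic ring. Within the data shown here, the only measured step touching this change runs the other way: a number 64 percentage points higher from compound 1 to compound 3 (beyond the scatter), a large weakening when a methyl was added. Among the measured compounds shown here, no measured pair shows the removal of a methyl from compound 1 itself, so the expectation rests on that one step read in reverse. Compound 4 is expected to keep or strengthen the effect, an estimated a number 6 percentage points lower from compound 1 to compound 4 (within the scatter), because a number 64 percentage points higher from compound 1 to compound 3 (beyond the scatter) shows how much one methyl mattered. Compound 4 is therefore estimated at 30%, within 8% to 65%.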

Compound 4, a percentage reported as activity, at one concentration (the size of the read-out at that concentration, not a potency): 56%
Compound 4: the middle estimate sits 26 percentage points below what was measured, within the range that was stated.
By their numbers in this assay, from the lowest: compound 1; then compound 4; then compounds 2 and 3 (each within the scatter of the next).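

In this assay, going from methoxy to hydroxy gives a number 20 percentage points higher from compound 1 to compound 4 (beyond the scatter), so removing this methyl weakens the effect rather than keeping or strengthening it. Adding a methyl to the hydroxy of compound 1 also weakens the effect, with a number 64 percentage points higher from compound 1 to compound 3 (beyond the scatter), so among these three compounds, changes in both directions move away from compound 1. Nothing here gives the reason for either weakening.

Still open, on these data alone, is how a longer chain, such as ethyl, on an oxygen on the aromatic ring would compare. As far as these compounds go, an amine in place of the hydroxy is equally open.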